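The compounds below may be only part of what the source reports. "The series", "measured", "known", "first", "only" and "open" are said of these compounds alone.

Measured in a functional assay on NCI-H460 cells (Homo sapiens) for cytotoxicity, read by sulforhodamine B assay; a higher number here means a weaker inhibitor of growth, a lower number a stronger inhibitor of growth:

compound 1 `CC1=CC[C@@H]([C@@](C)(O)CCCC(C)(C)NC(=S)N/N=C\c2ccc(C)cc2)CC1` gives 10100 nM
compound 2 `CC1=CC[C@@H]([C@@](C)(O)CCCC(C)(C)NC(=S)N/N=C\c2ccc(O)cc2)CC1` gives 1460 nM
compound 3 `CC1=CC[C@@H]([C@@](C)(O)CCCC(C)(C)NC(=S)N/N=C\c2ccc([N+](=O)[O-])cc2)CC1` gives 10100 nM

Compound 3 stands level with compound 1 at the digits shown, and the two together give the highest numbers of the three. Among the measured compounds shown here, the only compound apart from them is compound 2, and the step of a 6.9-fold higher number from compound 2 to compound 3 (0.84 log units; beyond the scatter) is beyond the scatter; the step of no change at the digits printed from compound 1 to compound 3 (within the scatter) is within it, as is the step of a 6.9-fold lower number from compound 1 to compound 2 (0.84 log units; beyond the scatter) in the other direction relative to compound 2.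

Compound 4 `CC1=CC[C@@H]([C@@](C)(O)CCCC(C)(C)NC(=S)N/N=C\c2ccccc2Cl)CC1` differs from compound 3 in one place: 2-chlorophenyl in place of 4-nitrophenyl on a carbon with a double bond to nitrogen. Of the measured steps, only those touching the group on this same carbon bear on it. The step of no change at the digits printed from compound 1 to compound 3 (within the scatter) shows that exchanging one group without hydrogen-bond donors for a nitro group left the number unchanged, whereas the step of a 6.9-fold higher number from compound 2 to compound 3 (0.84 log units; beyond the scatter) shows that only the hydroxy-bearing compound 2 gave a lower number. For the measured compounds named here, the entering 2-chlorophenyl carries no hydrogen-bond donors or acceptors, so no step beyond the scatter is expected in this assay; no measured compound carries a group on that ring in this position, so the range is kept wide. The estimated step is a 1.1-fold lower number from compound 3 to compound 4 (0.05 log units; within the scatter). Compound 4 is therefore expected to give about 9000 nM, within 3000 nM to 30000 nM.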

Compound 4, concentration for 50% growth inhibition: 24600 nM
The estimate for compound 4 lay 2.7-fold (0.44 log units) below the measured number; measured number inside the range.
By their numbers in this assay, from the lowest: compound 2; then compounds 1 and 3 (each within the scatter of the next); then compound 4.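

In this assay, the group on the carbon with a double bond to nitrogen now gives three levels of growth inhibition rather than two: 2-chlorophenyl in place of 4-nitrophenyl gives a 2.4-fold higher number from compound 3 to compound 4 (0.39 log units; beyond the scatter), in place of 4-methylphenyl it gives a 2.4-fold higher number from compound 1 to compound 4 (0.39 log units; beyond the scatter), and in place of 4-hydroxyphenyl it gives a 17-fold higher number from compound 2 to compound 4 (1.23 log units; beyond the scatter), which leaves compound 4 as the weakest inhibitor of growth of the four. The 4-nitrophenyl and 2-chlorophenyl groups both carry no hydrogen-bond donors, yet compound 3 and compound 4 differ beyond the scatter, so the absence of a donor on this ring does not by itself fix the number. No supporting measurement bears on these steps.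

Compound 4 differs from the others in both the substituent and its place on the ring, so the part played by chlorine and the part played by its place stay unseparated. From the compounds shown here alone, it remains open whether a methoxy group or an amine on this ring would stand with the hydroxy group of compound 2 or with the higher numbers of the other three compounds.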